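A few compounds are considered here, and "the series" means these few. Any claim that something is new, unique, unknown or untested is made for them only; others in the source may bear on it.

Among the compounds with values here, compound 2 `COc1cc(-c2nn(-c3cccc(NC(=O)Nc4cccc(C(F)(F)F)c4)c3)cc2-c2ccncc2)ccc1Cl` gives 794 nM in a functional assay on A549 cells (Homo sapiens) for inhibition, read by sulforhodamine B assay, with a stated time of 48 h (on this read-out lower numbers stand for stronger inhibition of growth and higher numbers for weaker inhibition of growth), and stands lowest of the two numbers measured so far; its nearest neighbour is compound 1 `O=C(Nc1cccc(-n2cc(-c3ccncc3)c(-c3ccc(Cl)c(O)c3)n2)c1)Nc1cccc(C(F)(F)F)c1`, which gives 1370 nM in this assay, and the step of a 1.7-fold lower number from compound 1 to compound 2 (0.24 log units; within the scatter) lies within the scatter. Compound 3 `COc1cc(-c2nn(-c3cccc(NC(=O)c4ccccc4)c3)cc2-c2ccncc2)ccc1Cl` has not yet been measured. It differs from compound 2 by phenyl in place of (3-(trifluoromethyl)phenyl)amino on a carbonyl carbon. Within the data shown here, the one measured step, from compound 1 to compound 2, concerns a methyl on an oxygen and says nothing about this change on the carbonyl carbon, so there is no measured step that bears on it, and the expectation rests on the structural change alone. Compound 3 is expected to give a somewhat higher number than compound 2, a step of a 3.1-fold higher number from compound 2 to compound 3 (0.50 log units; beyond the scatter), with a wide range. Compound 3 is therefore estimated at 2500 nM, between 800 nM and 8000 nM.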

Compound 3, concentration for 50% growth inhibition: 585 nM
Compound 3: the middle estimate sits 4.3-fold (0.63 log units) above what was measured; the whole stated range lies above it.
By their numbers in this assay, from the lowest: compounds 3, 2 and 1 (each within the scatter of the next, the first and the last beyond it).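

In this assay the change on the carbonyl carbon gives a 1.4-fold lower number from compound 2 to compound 3 (0.13 log units; within the scatter), so the two compounds cannot be told apart. The earlier pair spoke only to a methyl on an oxygen, whereas this pair shows that (3-(trifluoromethyl)phenyl)amino, with 11 heavy atoms and 1 hydrogen-bond donor, can be exchanged for phenyl, with 6 heavy atoms and 0 donors, while the number stays within the scatter. Nothing measured here explains this result.

This single exchange removes the trifluoromethyl group and the amino nitrogen together, so the pair cannot show what either contributes alone. On these data alone, how a methyl group or a chain ending in a dimethylamino group would read on the same carbonyl carbon also remains open.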